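Pyridin-3-yl for 4-chlorophenyl: what compound 4 may show

A few compounds are considered here, and "the series" means these few. Any claim that something is new, unique, unknown or untested is made for them only; others in the source may bear on it.

Of the compounds shown here, three sharing one core have been tested in a functional assay on A-375 cells (Homo sapiens) for antiproliferative activity, read by CCK-8 assay, with a stated time of 72 h, tested at 8 uM; a lower number here means a weaker effect, a higher number a stronger effect of the compound at the concentration tested. Compound 1 `Nc1ccccc1NC(=O)c1ccc(CSC(=S)N2CCN(C(c3ccccc3)c3ccccc3)CC2)cc1` gives 8.4%, compound 2 `Nc1ccccc1NC(=O)c1ccc(CSC(=S)N2CCN(c3ccc(Cl)cc3)CC2)cc1` gives 29%, and compound 3 `Nc1ccccc1NC(=O)c1ccc(CSC(=S)N2CCc3ccccc32)cc1` gives 85.4%. On these numbers compound 2 stands second highest of the three: its nearest neighbour is compound 1, whose value lies lower by an amount beyond the scatter, and its furthest is compound 3, whose value lies higher by an amount beyond the scatter. Compound 4 `Nc1ccccc1NC(=O)c1ccc(CSC(=S)N2CCN(c3cccnc3)CC2)cc1` has not yet been measured in this assay. It differs from compound 2 in one place: pyridin-3-yl in place of 4-chlorophenyl on an amine nitrogen in a ring. For the measured compounds named here, no step between measured compounds matches this change. The expected step of a number 7 percentage points lower from compound 2 to compound 4 (within the scatter) is small, slightly downward, and within the scatter. Compound 4 is therefore estimated at 22%, with a range from 5% to 45%.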

Compound 4, a percentage reported as inhibition, at one concentration (the size of the read-out at that concentration, not a potency): 88.8%
Beside the measured number, compound 4's estimate is 66.8 percentage points below it, and the stated range ends below it.
By their numbers in this assay, from the lowest: compound 1; then compound 2; then compounds 3 and 4 (each within the scatter of the next).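

In this assay, pyridin-3-yl in place of 4-chlorophenyl on an amine nitrogen in a ring gives a number 59.8 percentage points higher from compound 2 to compound 4 (beyond the scatter), so the read-out at this position can shift greatly with a change of one aromatic ring. The earlier compounds shown here offered no one-place step, so they could not show this. Nothing measured here accounts for the size of the step. The compounds shown leave open whether the ring nitrogen or the loss of chlorine matters more: unsubstituted phenyl would separate the two, while pyridin-2-yl and pyridin-4-yl would test where the ring nitrogen stands.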